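Swapping the piperidine amide for a methylsulfonylphenyl group

This account rests on a few compounds, and the source may have more. Where it says the series, first, only, none or still open, it means among the compounds named here.

Compound 1 `Cn1cncc1CN1CC(N(CC2CCN(C(=O)C(C)(C)C)CC2)S(=O)(=O)c2ccccn2)Cc2cc(C#N)ccc21` was tested in an ADME assay on Caco-2 cells (Homo sapiens) for permeability, in the apical to basolateral direction (a lower number here means that the compound crosses the layer more slowly, a higher number that the compound crosses the layer faster), where compound 1 gives 0.5 10^-6 cm/s. Compound 2 `Cn1cncc1CN1CC(N(CC2CCN(C(=O)c3ccco3)CC2)S(=O)(=O)c2ccccn2)Cc2cc(C#N)ccc21` gives 0.5 10^-6 cm/s, and compound 3 `Cn1cncc1CN1CC(N(CC2CCN(C(=O)OC(C)(C)C)CC2)S(=O)(=O)c2ccccn2)Cc2cc(C#N)ccc21` gives 15.5 10^-6 cm/s. Compound 1 therefore sits level with compound 2 at the low end of the three numbers; the step of no change at the digits printed from compound 1 to compound 2 (within the scatter) is within the scatter, whereas a 31-fold higher number from compound 1 to compound 3 (1.49 log units; beyond the scatter) is large. Compound 4 `Cn1cncc1CN1CC(N(Cc2ccc(S(C)(=O)=O)cc2)S(=O)(=O)c2ccccn2)Cc2cc(C#N)ccc21` differs from compound 1 at another place: 4-(methylsulfonyl)phenyl in place of 1-((tert-butyl)carbonyl)piperidin-4-yl on a saturated chain carbon bound to a sulfonamide nitrogen. Among the compounds with values here, no measured step touches this position; the steps from compound 1 to compound 2 and to compound 3 only show that small and large moves both occur. Compound 4 is expected to show a modest rise, a 3.0-fold higher number from compound 1 to compound 4 (0.48 log units; beyond the scatter), giving an estimated 1.5 10^-6 cm/s, with a range from 0.3 10^-6 cm/s to 8 10^-6 cm/s.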

Compound 4, apparent permeability: 0.2 10^-6 cm/s
Compound 4: middle estimate off by 7.5-fold (0.88 log units), on the high side, and the stated range ends above it.
By their numbers in this assay, from the lowest: compound 4; then compounds 1 and 2 (each within the scatter of the next); then compound 3.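

Within the data shown here, this is the first measured change at the saturated chain carbon bound to a sulfonamide nitrogen: in this assay, 4-(methylsulfonyl)phenyl in place of 1-((tert-butyl)carbonyl)piperidin-4-yl gives a 2.5-fold lower number from compound 1 to compound 4 (0.40 log units; beyond the scatter), a step beyond the scatter. The position therefore moves the number, and here the move is downward. Nothing available bears on why the number falls.

Still open, from the compounds shown here alone, is whether the lower number follows the phenyl ring or its methylsulfonyl group. A plain phenyl or a 4-methoxyphenyl at this place would separate the two.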